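Aryloxymethyl Variation on a Thiadiazole Carboxamide Series

The source may hold more compounds than are shown below. What is called first, only, known or untested is meant among the compounds shown, and "the series" means these compounds.

Measured compounds:
Compound 1 `O=C(O)CCc1ccc(NC(=O)c2nnc(COc3cccc(Cl)c3)s2)cc1` gives 1570 nM in a functional assay on CHO cells for agonist activity at Free fatty acid receptor 1 (Homo sapiens), read by FLIPR and calcium flux, tested at 1 uM; on this read-out higher numbers stand for an effect only at larger amounts of compound and lower numbers for an effect already at smaller amounts.
Compound 2 `Cc1ccc(OCc2nnc(C(=O)Nc3ccc(CCC(=O)O)cc3)s2)c(C)c1` gives 2540 nM in this assay.

Compound 1 holds the lowest of the two numbers in this assay, but its nearest neighbour compound 2 differs from it only by a 1.6-fold higher number from compound 1 to compound 2 (0.21 log units; within the scatter), so the two compounds cannot be set in order on the numbers shown. Among the measured compounds shown here, that one step, the exchange of an aryl group on an oxygen on a saturated carbon, is the only measured change that bears on the new compound.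

Compound 3 `Cc1ccc(OCc2nnc(C(=O)Nc3ccc(CCC(=O)O)cc3)s2)cc1` differs from compound 1 in one place: 4-methylphenyl in place of 3-chlorophenyl on an oxygen on a saturated carbon. The 4-methylphenyl group that enters shares one of the two methyl substituents of compound 2 and drops the chlorine of compound 1. Since the step from compound 1 to compound 2 stayed within the scatter, a step of similar modest size is expected here, with no clear direction beyond the scatter. Compound 3 is therefore estimated at 2000 nM in this assay, within 1000 nM to 4500 nM, which means an expected step of a 1.3-fold higher number from compound 1 to compound 3 (0.11 log units; within the scatter).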

Compound 3, half-maximal effective concentration: 2170 nM
Compound 3: the middle estimate sits 1.1-fold (0.04 log units) below what was measured; the measured number falls inside the stated range.
By their numbers in this assay, from the lowest: compounds 1, 3 and 2 (each within the scatter of the next).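

Setting 4-methylphenyl in place of 3-chlorophenyl on an oxygen on a saturated carbon comes with a 1.4-fold higher number from compound 1 to compound 3 (0.14 log units; within the scatter) in this assay and so gives a second exchange of the aryl group at this position that does not set the compounds apart. Among the compounds shown here, compound 3 also allows the first reading of a single methyl on this aryl group: hydrogen in place of methyl on an aromatic carbon comes with a 1.2-fold lower number from compound 2 to compound 3 (0.07 log units; within the scatter) and shows no difference that these numbers can resolve. No measurement offered here bears on why these three numbers lie so close together.

On these data alone, all three compounds carry a phenyl ring with chlorine or methyl on this oxygen, so it remains open whether a trifluoromethyl, a nitrile or an amine on that ring would give a step beyond the scatter. Also open, as far as these compounds go, is whether a longer chain in place of the saturated carbon would shift the number, since the shared core and the link to the oxygen are the same throughout.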